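A few compounds are considered here, and "the series" means these few. Any claim that something is new, unique, unknown or untested is made for them only; others in the source may bear on it.

Compound 1, `COc1cc(C)cc(-c2c(-c3ccnc(-c4ccc(C(C)=O)cc4)c3)cnn2CC#N)c1`, sits at the upper end of the two numbers at hand. In a functional assay on 786-0 cells (Homo sapiens) for cytotoxicity, read by sulforhodamine B assay, with a stated time of 48 h, tested at 100 nM (a higher number here means a weaker effect of the compound at the concentration tested, a lower number a stronger effect), compound 1 gives 88%, the highest figure among the measured pair. Within the data shown here, the only other measured compound, compound 2, `COc1cc(C)cc(-c2nn(CC#N)cc2-c2ccnc(-c3ccc(N(C)C)cc3)c2)c1`, gives 22% in this assay, a gap that lies beyond the scatter; the two structures differ in more than one place, so the numbers alone cannot be tied to a single change.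

The step now followed leads from compound 1 to compound 3, `COc1cc(C)cc(-c2c(-c3ccnc(-c4ccc(N(C)C)cc4)c3)cnn2CC#N)c1`. The change is dimethylamino in place of acetyl on an aromatic carbon. The group leaving carries one hydrogen-bond acceptor, as does the group entering, and the place, para to a large group, stays the same.

Among the measured compounds shown here, no measured pair shows this change in isolation. Compound 2, which carries the dimethylamino group, gives 22%, and that figure is the only indication available. Compound 3 is therefore expected to read lower than compound 1, with the estimated step of a number 43 percentage points lower from compound 1 to compound 3 (beyond the scatter) beyond the scatter. For compound 3 the estimate in this assay is 45%, within a range of 20% to 78%.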

Compound 3, a percentage reported as activity, at one concentration (the size of the read-out at that concentration, not a potency): 6%
The estimate for compound 3 lay 39 percentage points above the measured number; the measured number lies below the stated range.
By their numbers in this assay, from the lowest: compound 3; then compound 2; then compound 1.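

The exchange of acetyl for dimethylamino, para to a large group, can now be read as a single change on the core of compound 1: in this assay it gives a number 82 percentage points lower from compound 1 to compound 3 (beyond the scatter), a large step that the earlier pair, differing in more than one place, could not isolate. The leaving and entering groups match in their counts of heavy atoms and hydrogen-bond acceptors, and neither carries a hydrogen-bond donor or a net charge, yet the read-out at this place is far from indifferent to the exchange. Nothing at hand explains the size of this step.

The compounds shown leave open whether this step belongs to dimethylamino itself or would also appear with another amine on the same aromatic carbon, such as methylamino, a primary amine or morpholine. They also leave open how the read-out would respond to a carboxylic acid at this place, and whether acetyl and dimethylamino would differ as much with the nitrile-bearing cyanomethyl chain replaced by a longer chain.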